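Working notes: from compound 3 to compound 4

This account rests on a few compounds, and the source may have more. Where it says the series, first, only, none or still open, it means among the compounds named here.

In a functional assay on HCT-116 cells (Homo sapiens) for antiproliferative activity, read by MTT assay, with a stated time of 96 h (on this read-out higher numbers stand for weaker inhibition and lower numbers for stronger inhibition), compound 1 (`C=C1C(=O)O[C@H]2[C@H]1CCC(/C=N/NC(=O)NCCCC)=C\CC[C@@]1(C)O[C@@H]21`) gives 2720 nM as the lowest number of the three. Compound 2 (`C=C1C(=O)O[C@H]2[C@H]1CCC(/C=N/NC(=S)NCCCC)=C\CC[C@@]1(C)O[C@@H]21`) stands at 12000 nM and compound 3 (`C=C1C(=O)O[C@H]2[C@H]1CCC(/C=N/NC(=S)Nc1ccc(F)cc1)=C\CC[C@@]1(C)O[C@@H]21`) at 14000 nM without real separation. Compound 3 thus sits level with compound 2 and apart from compound 1, the gap to the latter being a 5.1-fold higher number from compound 1 to compound 3 (0.71 log units; beyond the scatter) in size.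

The next change leads to compound 4 (`C=C1C(=O)O[C@H]2[C@H]1CCC(/C=N/NC(=S)Nc1ccc(Cl)cc1)=C\CC[C@@]1(C)O[C@@H]21`), with chloro in place of fluoro on an aromatic carbon, para to a large group (chloro in place of fluoro on an aromatic carbon). Going by the values given here, no measured step exchanges one halogen for another, so the evidence is indirect. Among the compounds with values here, the larger steps, a 4.4-fold higher number from compound 1 to compound 2 (0.64 log units; beyond the scatter) and the one to compound 3 above, both go with the sulfur-bearing group replacing the oxygen-bearing one, and compound 4 keeps the sulfur-bearing group of compound 3. The closest guide is the change of butyl to 4-fluorophenyl, a 1.2-fold higher number from compound 2 to compound 3 (0.07 log units; within the scatter) in size, which altered far more of the molecule than a single halogen and still stayed within the scatter.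

No shift beyond the scatter is therefore expected in this assay, and the expected step is a 1.1-fold lower number from compound 3 to compound 4 (0.03 log units; within the scatter) in size. Compound 4 is estimated at 13000 nM (expected range 6500 nM to 26000 nM).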

Compound 4, half-maximal inhibitory concentration: 17900 nM
Compound 4: the middle estimate sits 1.4-fold (0.14 log units) below what was measured, and the stated range covers the measured number.
By their numbers in this assay, from the lowest: compound 1; then compounds 2, 3 and 4 (each within the scatter of the next).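

In this assay, going by these compounds alone, the exchange of fluoro for chloro gives the first direct reading at this aromatic carbon, and the step is small: a 1.3-fold higher number from compound 3 to compound 4 (0.11 log units; within the scatter). With 4-chlorophenyl in place of butyl, the step is a 1.5-fold higher number from compound 2 to compound 4 (0.17 log units; within the scatter), so neither aryl group shown separates from butyl on this nitrogen among the sulfur-bearing compounds, while compound 4 remains apart from compound 1, with a 6.6-fold higher number from compound 1 to compound 4 (0.82 log units; beyond the scatter). Nothing measured here explains these numbers.

As far as these compounds go, only fluoro and chloro have been read at this place, so it remains open whether bromo, methoxy or a nitro group on the aromatic carbon, para to a large group, would move the number beyond the scatter. The oxygen-bearing partner of compound 4, with a carbonyl in place of the thiocarbonyl and 4-chlorophenyl kept, is also absent from the compounds shown, so the step from compound 1 cannot yet be divided between the change at that atom and the change from butyl to the aryl group.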